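Terminal Trifluoromethyl Swapped for Propyl on a Long Chain

A few compounds are considered here, and "the series" means these few. Any claim that something is new, unique, unknown or untested is made for them only; others in the source may bear on it.

Compound 2 `FC(F)(F)CCCCCCCOc1ccc(-c2nnn(CCCCc3nnn[nH]3)n2)cc1` stands lowest of the two compounds measured in a functional assay for antagonist activity at cysteinyl leukotriene receptor 1 (Cavia porcellus); a higher number here means a more potent compound, by a factor of ten per unit of this negative logarithm, a lower number a less potent compound; compound 2 gives 5.43. Its nearest neighbour is compound 1 `FC(F)(F)CCCCCOc1ccc(-c2nnn(CCCCc3nnn[nH]3)n2)cc1`, which in this assay gives 5.82, and the step of a number 0.39 log units lower from compound 1 to compound 2 (beyond the scatter) came with 3,3,3-trifluoropropyl in place of trifluoromethyl on a saturated chain carbon, five bonds along the chain from an oxygen on an aromatic ring. Compound 3 `CCCCCCCCCCOc1ccc(-c2nnn(CCCCc3nnn[nH]3)n2)cc1` differs from compound 2 by propyl in place of trifluoromethyl on a saturated chain carbon, seven bonds along the chain from an oxygen on an aromatic ring. Among the measured compounds shown here, no measured step exchanges fluorine for hydrogen on the chain; the only step on record alters chain length, and it was modest. Compound 3 is therefore expected to sit close to compound 2, with the step of a number 0.07 log units higher from compound 2 to compound 3 (within the scatter) judged likely to stay within the scatter. The estimate for compound 3 in this assay is 5.5, ranging from 5 to 6.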

Compound 3, negative logarithm of the antagonist equilibrium constant: 5.09
For compound 3 the middle estimate is 0.41 log units above the measured one, and the stated range covers the measured number.
By their numbers in this assay, from the lowest: compound 3; then compound 2; then compound 1.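

In this assay, replacing the terminal trifluoromethyl with propyl at this place was not neutral, giving a number 0.34 log units lower from compound 2 to compound 3 (beyond the scatter), whereas the earlier pair had shown only a change of chain length with the trifluoromethyl kept. Against the shorter chain, pentyl in place of trifluoromethyl gave a number 0.73 log units lower from compound 1 to compound 3 (beyond the scatter), so among these three compounds the two chains ending in trifluoromethyl both stand above the chain without fluorine, and no compound here goes against that order. Nothing measured here explains either step.

The compounds shown leave open whether the trifluoromethyl end itself matters at other chain lengths, since no chain without fluorine is paired with compound 1 at equal length. They also leave open how a chain ending in a hydroxyl or a carboxylic acid would compare at this place.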